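The source may hold more compounds than are shown below. What is called first, only, known or untested is meant among the compounds shown, and "the series" means these compounds.

Compound 1 `N#CC1=C(N)Oc2c(N)cc3nc4ccccc4nc3c2C12C(=O)N(Cc1cnnn1-c1ccc(Cl)cc1)c1ccccc12` gives > 50000 nM in an ADME assay on HUVEC cells (Homo sapiens) for antiproliferative activity, read by MTT assay, with a stated time of 48 h (a higher number here means a weaker inhibitor, a lower number a stronger inhibitor), which is a limit of the assay and not a number.
Compound 2 `CC(=O)Nc1ccc(-n2nncc2CN2C(=O)C3(C(C#N)=C(N)Oc4c(N)cc5nc6ccccc6nc5c43)c3ccccc32)cc1` gives > 50000 nM in this assay, again a limit and not a number.

Among the compounds with values here, compound 2 therefore stands at the ceiling of what the assay reports, and it shares that position with the only other measured compound: both values sit at the limit of > 50000 nM in this assay, at which 2 of the 2 values shown sit. Within the data shown here, the one measured step, a step that the two limits leave unreadable from compound 1 to compound 2, is consequently unreadable in size and direction, since the two limits hide any difference that may exist between them.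

Compound 3 `CCOc1ccc(-n2nncc2CN2C(=O)C3(C(C#N)=C(N)Oc4c(N)cc5nc6ccccc6nc5c43)c3ccccc32)cc1` differs from compound 2 in a single place: ethoxy in place of acetamido on an aromatic carbon. Among the measured compounds shown here, no measured step bears readably on this change, because the only step available, a step that the two limits leave unreadable from compound 1 to compound 2, is itself hidden by the two limits. With nothing to point away from the ceiling, compound 3 is expected to remain there, and the step of a number no higher from compound 2 to compound 3 (the limit leaves the size open) is estimated to be none beyond the scatter. Compound 3 is therefore expected to give about 50000 nM in this assay, in the range 15000 nM to 150000 nM, most likely reported only as a limit.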

Compound 3, half-maximal inhibitory concentration: > 50000 nM
Compound 3 was reported as a limit; the forecaster's own chance of this, stated with the estimate: 75%; the middle value lies on the limit itself.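

Compound 3 also gives only a limit and not a number, > 50000 nM in this assay. Within the data shown here, no step among compound 1, compound 2 and compound 3 can therefore be read, in size or in direction: the limit of > 50000 nM in this assay, at which 3 of the 3 values shown sit. The compounds shown leave open how far these three truly differ, and whether any group at this place would give a measurable value in this assay.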